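The compounds below may be only part of what the source reports. "The series", "measured", "known", "first", "only" and "open" are said of these compounds alone.

Compound 1 `CC1=C(C(=O)OCC(C)C)C(c2ccco2)NC(=S)N1` gives 18% in an assay on membranes from HEK293 cells for displacement of a labelled ligand from adenosine receptor A2b (Homo sapiens), read by scintillation counting, with a stated time of 30 min, tested at 1 uM; on this read-out higher numbers stand for more inhibition at the one concentration tested (going by the name of the read-out) and lower numbers for less inhibition.
Compound 2 `CC1=C(C(=O)OCc2ccccc2)C(c2ccco2)NC(=S)N1` gives 41% in this assay.

Compound 1 stands lowest of these two numbers. Within the data shown here, the one measured step, a number 23 percentage points higher from compound 1 to compound 2 (beyond the scatter), concerns the ester part of the shared core and not the ring on the saturated ring carbon, so it does not bear on the change at hand. Among the measured compounds shown here, compound 3 `CC1=C(C(=O)OCC(C)C)C(c2ccsc2)NC(=S)N1` differs from compound 1 in this way: thiophen-3-yl in place of furan-2-yl on a saturated ring carbon With no measured step covering this swap, the expectation rests on compound 1 alone, and a step not beyond the scatter is expected, a number 4 percentage points higher from compound 1 to compound 3 (within the scatter). Compound 3 is therefore estimated at 22%, with a range from 5% to 42%.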

Compound 3, a percentage reported as inhibition, at one concentration (the size of the read-out at that concentration, not a potency): 15%
Estimate against measurement, compound 3: 7 percentage points above; the measured number falls inside the stated range.
By their numbers in this assay, from the lowest: compounds 3 and 1 (each within the scatter of the next); then compound 2.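

In this assay, putting thiophen-3-yl in place of furan-2-yl on the saturated ring carbon gives a number 3 percentage points lower from compound 1 to compound 3 (within the scatter), so at this position, one five-membered aromatic ring can replace the other without a change beyond the scatter. This swap also changes the ring's hetero atom from oxygen to sulfur and where the ring is attached, yet the read-out does not separate these two differences. No evidence here explains the result.

Still open, on these data alone, is whether a phenyl ring or a chain carrying an amine at this position would move the number. Also open, as far as these compounds go, is whether thiophen-3-yl gives the same result alongside the ester of compound 2.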